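From compound 2 to compound 4: a sulfonyl group exchanged

The source may report more compounds than this note shows. Statements on the series, on what has been measured and on what is new or still open speak of the compounds shown alone.

Compound 1 `CNCc1cc(-c2cccnc2F)n(S(=O)(=O)c2cccnc2)c1`: -0.85
Compound 2 `CNCc1cn(S(=O)(=O)c2ccoc2)c(-c2cccnc2F)c1F`: 0.45
Compound 3 `CNCc1cn(S(=O)(=O)c2cc(OC)ccn2)c(-c2cccnc2F)c1F`: 0.51

In a physicochemical assay for lipophilicity, read by HPLC, at pH 7.4 (a higher number here means a more lipophilic compound, a lower number a more polar compound), compound 2 stands level with compound 3, within the scatter, while compound 1 lies far lower. Compound 4 `CNCc1cn(S(=O)(=O)c2cccc(C)n2)c(-c2cccnc2F)c1F` has not yet been measured. It departs from compound 2 in one place: 6-methylpyridin-2-yl in place of furan-3-yl on a sulfonyl sulfur. That is, 6-methylpyridin-2-yl takes the place of furan-3-yl on a sulfonyl sulfur. Among the measured compounds shown here, the one measured step that bears on this is a number 0.06 log units higher from compound 2 to compound 3 (within the scatter), which also replaces furan-3-yl on a sulfonyl sulfur. For the measured compounds named here, compound 1 differs from compound 2 in more than one place and offers no such step. No step beyond the scatter is therefore expected in this assay. The expected change is a number 0.15 log units higher from compound 2 to compound 4 (within the scatter). The estimate for compound 4 is 0.6, with an expected range from 0.2 to 1.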

Compound 4, distribution coefficient: 0.71
Compound 4: middle estimate off by 0.11 log units, on the low side, within the range that was stated.
By their numbers in this assay, from the lowest: compound 1; then compounds 2, 3 and 4 (each within the scatter of the next).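

In this assay the sulfonyl sulfur took a second replacement of furan-3-yl with no step beyond the scatter: the number moves a number 0.26 log units higher from compound 2 to compound 4 (within the scatter) and, between the two six-membered cases, a number 0.20 log units higher from compound 3 to compound 4 (within the scatter). Compound 2, compound 3 and compound 4 thus stand within the scatter of one another, with three different aromatic groups at this place. Nothing at hand explains why these groups read alike. Still open, from the compounds shown here alone, is whether a carboxylic acid, an amine or a longer chain on the sulfonyl sulfur would bring a step beyond the scatter.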